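Swapping the hydroxylated tail of compound 2

The compounds below may be only part of what the source reports. "The series", "measured", "known", "first", "only" and "open" are said of these compounds alone.

Compound 1 `COc1cc(NC(C)CCCNC(=O)NNC(=O)NC(CO)(CO)CO)c2ncccc2c1`: > 100000 nM
Compound 2 `COc1cc(NC(C)CCCNC(=O)NNC(=O)N(CCO)CCO)c2ncccc2c1`: > 100000 nM

In a functional assay on NCI-H460 cells (Homo sapiens) for inhibition, read by MTT assay, with a stated time of 4 days (on this read-out lower numbers stand for stronger inhibition and higher numbers for weaker inhibition), compound 2 gives > 100000 nM, which is a limit of the assay and not a number. Compound 1 gives > 100000 nM, which is a limit too. The picture so far is therefore (the limit of > 100000 nM in this assay, at which 2 of the 2 values shown sit).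

Compound 3 `COc1cc(NC(C)CCCNC(=O)NNC(=O)NCCCO)c2ncccc2c1` differs from compound 2 in one place, on a carbonyl carbon: (3-hydroxypropyl)amino in place of bis(2-hydroxyethyl)amino on a carbonyl carbon.

Among the compounds with values here, the one measured step that bears on this change is a step that the two limits leave unreadable from compound 1 to compound 2. It changed the group at the same place, but it gives neither a size nor a direction to carry over. With compound 2 at > 100000 nM, no clear step is expected in this assay.

The estimated value for compound 3 is 100000 nM, with a range from 40000 nM to 200000 nM. This estimate means an expected a number no higher from compound 2 to compound 3 (the limit leaves the size open).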

Compound 3, half-maximal inhibitory concentration: > 100000 nM
Compound 3 gave a limit, no number (the forecaster's own chance of this, stated with the estimate: 80%); the middle value lies on the limit itself.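

Compound 3 gives a limit and not a number, as do compound 1 and compound 2, so no step among these three compounds can be read: the limit of > 100000 nM in this assay, at which 3 of the 3 values shown sit. In this assay the compounds shown leave open whether the three hydroxylated tails differ at all.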